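Removing a fluorine from the benzyl amide of compound 1

The compounds below may be only part of what the source reports. "The series", "measured", "known", "first", "only" and "open" are said of these compounds alone.

Measured so far:
- compound 1, `COc1ccc2c(=O)c(/C=C/C(=O)NCc3cccc(F)c3)coc2c1`: 475000 nM
- compound 2, `COc1ccc2c(=O)c(/C=C/C(=O)Nc3cc(C)ccc3C)coc2c1`: 1100000 nM

Both compounds were tested in an ADME assay on HepG2 2.2.15 cells (Homo sapiens) for cytotoxicity, read by MTT assay, with stated times of 48 h and 9 days; a higher number here means that more compound is tolerated, a lower number that less compound is tolerated. Compound 1 gives 475000 nM, the lower of the two numbers, so less of it is tolerated by the cells than of compound 2, which gives 1100000 nM. Among the measured compounds shown here, the single measured step, a 2.3-fold higher number from compound 1 to compound 2 (0.36 log units; beyond the scatter), comes from exchanging the whole amide substituent.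

Compound 3, `COc1ccc2c(=O)c(/C=C/C(=O)NCc3ccccc3)coc2c1`, differs from compound 1 in a smaller way: hydrogen in place of fluoro on an aromatic carbon. For the measured compounds named here, the one known step does not touch this change directly, since it replaced 3-fluorobenzyl by 2,5-dimethylphenyl rather than simply taking the fluoro away, and even that larger exchange moved this assay only modestly. Removing a single fluorine from the benzyl group is therefore expected to leave the result near that of compound 1, with no step beyond the scatter.

Compound 3 is thus estimated at 500000 nM, within 250000 nM to 1000000 nM, which means an expected step of a 1.1-fold higher number from compound 1 to compound 3 (0.02 log units; within the scatter).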

Compound 3, half-maximal cytotoxic concentration: 376000 nM
Compound 3: middle estimate off by 1.3-fold (0.12 log units), on the high side; measured number inside the range.
By their numbers in this assay, from the lowest: compounds 3 and 1 (each within the scatter of the next); then compound 2.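

In this assay, the fluoro on the benzyl group of compound 1 turns out to matter little at this meta position, since hydrogen in its place gives a 1.3-fold lower number from compound 1 to compound 3 (0.10 log units; within the scatter). The new comparison also shows that the gap to compound 2 remains once the fluoro is gone, with benzyl in place of 2,5-dimethylphenyl on the amide nitrogen giving a 2.9-fold lower number from compound 2 to compound 3 (0.47 log units; beyond the scatter), so among these three compounds the two benzyl amides sit together and below compound 2. No measurement at hand explains this difference in how well the cells tolerate the compounds.

From the compounds shown here alone, what stays open is whether any other group at this place on the ring, such as a methoxy group or an amine, would shift the number beyond the scatter, as neither fluoro nor hydrogen does. Going by these compounds, it is also open whether the difference from compound 2 follows the methyl groups or the benzyl-to-phenyl exchange, and how a phenethyl group on the amide nitrogen would compare with benzyl.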